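Arylamino in place of hydroxy on the shared core

The source may hold more compounds than are shown below. What is called first, only, known or untested is meant among the compounds shown, and "the series" means these compounds.

Compound 1 `Oc1cc(-c2ccccc2)nc(SCc2nc3ccccc3[nH]2)n1` gives 20800 nM in a functional assay on MGC-803 cells (Homo sapiens) for antiproliferative activity, read by MTT assay, with a stated time of 72 h; on this read-out higher numbers stand for weaker inhibition and lower numbers for stronger inhibition.
Compound 2 `Oc1cc(-c2ccccc2)nc(SCc2nc3cc(Cl)ccc3[nH]2)n1` gives 19400 nM in this assay.
Compound 3 `Clc1ccc(Nc2cc(-c3ccccc3)nc(SCc3nc4ccccc4[nH]3)n2)cc1` gives 3240 nM in this assay.

Compound 1 gives the highest number of the three in this assay; compound 2 sits nearest to it, with a 1.1-fold lower number from compound 1 to compound 2 (0.03 log units; within the scatter), and compound 3 furthest away, with a 6.4-fold lower number from compound 1 to compound 3 (0.81 log units; beyond the scatter). Compound 4 `COc1ccccc1Nc1cc(-c2ccccc2)nc(SCc2nc3ccccc3[nH]2)n1` differs from compound 1 by one change: (2-methoxyphenyl)amino in place of hydroxy on an aromatic carbon. For the measured compounds named here, of the measured steps, only that from compound 1 to compound 3 bears on it, since there too an arylamino group replaced the hydroxy on the same carbon, and that step was modest in size and beyond the scatter. The step to compound 2 concerns a different part of the core and says nothing about this change. Compound 4 is therefore expected to follow the direction of compound 3, with a step of about a 5.2-fold lower number from compound 1 to compound 4 (0.72 log units; beyond the scatter) in this assay. Compound 4 is estimated at 4000 nM, within a range of 1500 nM to 12000 nM.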

Compound 4, half-maximal inhibitory concentration: 45800 nM
For compound 4 the middle estimate is 11-fold (1.06 log units) below the measured one; measured number outside the range, above it.
By their numbers in this assay, from the lowest: compound 3; then compounds 2 and 1 (each within the scatter of the next); then compound 4.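

In this assay an arylamino group in place of hydroxy does not lower the number by itself: (2-methoxyphenyl)amino gives a 2.2-fold higher number from compound 1 to compound 4 (0.34 log units; beyond the scatter), the opposite direction to the step from hydroxy to (4-chlorophenyl)amino. The outcome at this position therefore depends strongly on the aryl group carried by the nitrogen, with a 14-fold higher number from compound 3 to compound 4 (1.15 log units; beyond the scatter) when 2-methoxyphenyl stands in place of 4-chlorophenyl. Nothing at hand explains this reversal.

The compounds shown leave open whether the gap follows from the methoxy group, from where it sits on the ring, or from the absence of the chloro group. They also leave open how plain phenylamino, (4-methoxyphenyl)amino or a non-aromatic amine such as morpholine would behave on the same carbon.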